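Swapping the amide aryl group on a naphthyl thiazolidinedione

A few compounds are considered here, and "the series" means these few. Any claim that something is new, unique, unknown or untested is made for them only; others in the source may bear on it.

The series is built around a shared core bearing a thiazolidinedione and an ether-linked amide. Compound 1 `O=C(CN1C(=O)S/C(=C/c2ccccn2)C1=O)Nc1nc2ccccc2s1` carries a different arrangement and gives 9300 nM in an assay on isolated protein for inhibition of histone deacetylase 4 (Homo sapiens), with a stated time of 1 h; a lower number here means a stronger inhibitor, a higher number a weaker inhibitor. Compound 2 `Cc1cccc(NC(=O)COc2ccc3cc(/C=C4/SC(=O)NC4=O)ccc3c2)n1` gives 1100 nM in this assay, the lowest of the three numbers; compound 3 `Cc1cc(NC(=O)COc2ccc3cc(/C=C4/SC(=O)NC4=O)ccc3c2)no1` gives 1700 nM, close to compound 2, while compound 1 is the furthest away. Within the data shown here, the one step within the scatter, a 1.5-fold higher number from compound 2 to compound 3 (0.19 log units; within the scatter), shows that swapping one small aromatic group for another on the amide-type nitrogen barely moved the number.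

Compound 4 `O=C(COc1ccc2cc(/C=C3/SC(=O)NC3=O)ccc2c1)Nc1ccc(Br)c(Br)c1` differs from compound 2 by 3,4-dibromophenyl in place of 6-methylpyridin-2-yl on an amide-type nitrogen. Among the measured compounds shown here, only the step from compound 2 to compound 3 bears on this change, and it lay within the scatter, though the entering group here has no hydrogen-bond acceptor and carries two bromines, a larger departure than before. A small step is therefore expected in this assay, leaning toward a higher number, estimated as a 1.4-fold higher number from compound 2 to compound 4 (0.13 log units; within the scatter). Compound 4 is accordingly expected to give about 1500 nM in this assay, with a range from 500 nM to 4500 nM.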

Compound 4, half-maximal inhibitory concentration: 4900 nM
Compound 4: the middle estimate sits 3.3-fold (0.51 log units) below what was measured; measured number outside the range, above it.
By their numbers in this assay, from the lowest: compounds 2 and 3 (each within the scatter of the next); then compounds 4 and 1 (each within the scatter of the next).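

The amide-type nitrogen of this series proved less tolerant than the first pair suggested: in this assay, 3,4-dibromophenyl raises the number over both earlier groups (a 4.5-fold higher number from compound 2 to compound 4 (0.65 log units; beyond the scatter) and a 2.9-fold higher number from compound 3 to compound 4 (0.46 log units; beyond the scatter)), although 6-methylpyridin-2-yl and 5-methyl-1,2-oxazol-3-yl had stayed within the scatter of each other. The substituent on this nitrogen can therefore shift the number beyond the scatter, and here the shift is in the direction of weaker inhibition, though it remains modest. No measurement is available to explain why the dibromophenyl group gives the higher number.

The change from compound 2 to compound 4 exchanges a ring with a hetero atom for one of carbon only and also replaces the methyl with the bromines, so the compounds shown cannot separate these differences. A plain phenyl, a bromopyridinyl group, or a phenyl bearing an amine or a carboxylic acid on this nitrogen would show which of them accounts for the step and whether any group here can bring the number below that of compound 2.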